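A few compounds are considered here, and "the series" means these few. Any claim that something is new, unique, unknown or untested is made for them only; others in the source may bear on it.

Measured in a functional assay on UACC-62 cells (Homo sapiens) for inhibition, read by sulforhodamine B assay, with a stated time of 48 h; a higher number here means that more compound is tolerated, a lower number that less compound is tolerated:

- compound 1 `O=C(Nc1cccc(-n2cc(-c3ccncc3)c(-c3ccc(Cl)c(O)c3)n2)c1)Nc1cccc(C(F)(F)F)c1`: 21900 nM
- compound 2 `COc1cc(-c2nn(-c3cccc(NC(=O)Nc4cccc(C(F)(F)F)c4)c3)cc2-c2ccncc2)ccc1Cl`: 3480 nM
- compound 3 `O=C(Nc1cccc(-n2cc(-c3ccncc3)c(-c3ccc(Cl)c(O)c3)n2)c1)Nc1cc(C(F)(F)F)cc(C(F)(F)F)c1`: 8460 nM

Among these three, compound 1 stands highest at 21900 nM, so it is the most tolerated of the set. Both measured changes to it lead downward. The next compound, compound 4 `O=C(Nc1cccc(-n2cc(-c3ccncc3)c(-c3ccc(Cl)c(O)c3)n2)c1)Nc1ccc(Cl)c(C(F)(F)F)c1`, keeps the core of compound 1 and carries chloro in place of hydrogen on an aromatic carbon, ortho to a trifluoromethyl group and para to a large group (chloro in place of hydrogen on an aromatic carbon). The 3-(trifluoromethyl)phenyl group thus becomes 4-chloro-3-(trifluoromethyl)phenyl.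

Among the measured compounds shown here, the closest precedent is a 2.6-fold lower number from compound 1 to compound 3 (0.41 log units; beyond the scatter), a modest step that also adds a substituent to this same 3-(trifluoromethyl)phenyl group. The other measured step, a 6.3-fold lower number from compound 1 to compound 2 (0.80 log units; beyond the scatter), is larger, but it changes a different part of the molecule and so bears on compound 4 only weakly. With a single precedent on this group, the expectation is a modest move downward, of about the size seen for compound 3. The estimated change is a 2.2-fold lower number from compound 1 to compound 4 (0.34 log units; beyond the scatter). For compound 4 the expected value is 10000 nM, with an estimated range from 4500 nM to 22000 nM.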

Compound 4, concentration lethal to 50% of the cells: 3160 nM
Beside the measured number, compound 4's estimate is 3.2-fold (0.50 log units) above it, outside the stated range (below it).
By their numbers in this assay, from the lowest: compounds 4 and 2 (each within the scatter of the next); then compound 3; then compound 1.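

In this assay, chloro in place of hydrogen on the 3-(trifluoromethyl)phenyl group, ortho to the trifluoromethyl group and para to a large group, gives a 6.9-fold lower number from compound 1 to compound 4 (0.84 log units; beyond the scatter). This shows that a single added chlorine on this group can move the number further than the added trifluoromethyl of the earlier step, a 2.6-fold lower number from compound 1 to compound 3 (0.41 log units; beyond the scatter), so the larger entering group does not give the larger step in this pair of changes. Because those two steps differ in both the entering group and its place on the ring, they cannot separate the effect of the group from that of its position, and nothing measured here explains the drop in the number.

As far as these compounds go, it remains open whether fluoro, methyl or a nitrile at this same position would give a step like that of chloro, or whether the effect is particular to chlorine. Also open, from the compounds shown here alone, is how the chloro change would combine with the methyl on the oxygen seen in compound 2, and whether the two steps would add up on the shared core.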